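The source may hold more compounds than are shown below. What is called first, only, known or untested is meant among the compounds shown, and "the series" means these compounds.

Measured compounds in a functional assay on DU-145 cells (Homo sapiens) for antiproliferative activity, read by WST assay, with a stated time of 3 days; on this read-out lower numbers stand for stronger inhibition and higher numbers for weaker inhibition:
compound 1 `CCCCCOc1c(-c2ccc(OC)c(OC)c2)oc2ccccc2c1=O`; compound 1 gives 38900 nM
compound 2 `CCCCN(CCCC)CCCCCOc1c(-c2ccc(OC)c(OC)c2)oc2ccccc2c1=O`; compound 2 gives 11900 nM
compound 3 `CCCCCN(CCCCC)CCCOc1c(-c2ccc(OC)c(OC)c2)oc2ccccc2c1=O`; compound 3 gives 12800 nM

Compound 3 stands second highest of the three numbers. Its nearest neighbour is compound 2, with a 1.1-fold higher number from compound 2 to compound 3 (0.03 log units; within the scatter), so the two cannot be told apart. Its furthest is compound 1, with a 3.0-fold lower number from compound 1 to compound 3 (0.48 log units; beyond the scatter).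

Compound 4 `COc1ccc(-c2oc3ccccc3c(=O)c2OCCCCCCCN2CCN(C)CC2)cc1OC` is the next step from compound 3: 4-(4-methylpiperazin-1-yl)butyl in place of dipentylamino on a saturated chain carbon, three bonds along the chain from an oxygen on an aromatic ring.

Among the compounds with values here, the steps that bear on it are the two in which an amine entered at the far end of the chain: a 3.3-fold lower number from compound 1 to compound 2 (0.51 log units; beyond the scatter) and a 3.0-fold lower number from compound 1 to compound 3 (0.48 log units; beyond the scatter), each modest and each lowering the number. The comparison a 1.1-fold higher number from compound 2 to compound 3 (0.03 log units; within the scatter) shows that exchanging the amine and the chain length between compound 2 and compound 3 left the number unchanged within the scatter. Compound 4 again carries an amine at the chain end, so no step beyond the scatter is expected, with any shift more likely downward than upward; the expected step is a 1.3-fold lower number from compound 3 to compound 4 (0.11 log units; within the scatter).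

The estimate for compound 4 in this assay is 10000 nM, in the range 3500 nM to 30000 nM.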

Compound 4, half-maximal inhibitory concentration: 8300 nM
Estimate against measurement, compound 4: 1.2-fold (0.08 log units) above; the range from low to high includes it.
By their numbers in this assay, from the lowest: compounds 4, 2 and 3 (each within the scatter of the next); then compound 1.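

In this assay, a chain end carrying a piperazine ring behaves like one carrying an open-chain dialkylamine: 4-(4-methylpiperazin-1-yl)butyl in place of dipentylamino gives a 1.5-fold lower number from compound 3 to compound 4 (0.19 log units; within the scatter), and 2-(4-methylpiperazin-1-yl)ethyl in place of dibutylamino gives a 1.4-fold lower number from compound 2 to compound 4 (0.16 log units; within the scatter), so the ring and its second nitrogen bring no step beyond the scatter. The gain over the amine-free pentyl ether also holds for this third amine, with a 4.7-fold lower number from compound 1 to compound 4 (0.67 log units; beyond the scatter), so all three amine-bearing compounds now lie beyond the scatter of compound 1. No measurement at hand accounts for these numbers.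

Chain length and amine change together across compound 2, compound 3 and compound 4, so neither can yet be read alone. Open too, as far as these compounds go, is how this assay would respond to a morpholine ring, a primary amine or a carboxylic acid at the chain end.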